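Carbamate on the pyrimidine core: expectation for compound 3

A few compounds are considered here, and "the series" means these few. Any claim that something is new, unique, unknown or untested is made for them only; others in the source may bear on it.

Two members of this series carry numbers in a functional assay on the whole organism for inhibition, with Rattus norvegicus as the target, with stated times of 1 h and 3.5 h, at a dose of 100 mg/kg by the oral route (a higher number here means more inhibition at the dose given (going by the name of the read-out), a lower number less inhibition), so far. Compound 1, `Cc1cncnc1-c1ccccc1`, gives 48% in this assay. Compound 2, `CC(C)(C)c1ncncc1-c1ccccc1`, gives 48% in this assay, level with compound 1 at the digits shown; its nearest neighbour is compound 1, and the two values fall within the usual scatter of each other. Among the measured compounds shown here, no step between measured compounds that differ in one place is available, so the series gives no measured direction yet.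

Compound 3, `CCOC(=O)Nc1ncc(-c2ccccc2)c(C(C)(C)C)n1`, is not yet measured in this assay. It differs from compound 2 in one place: (ethoxycarbonyl)amino in place of hydrogen on an aromatic carbon. The change adds one hydrogen-bond donor and two acceptors to the core of compound 2 at the carbon between two ring nitrogen atoms.

With nothing in the measured pairs to anchor the size of such a change, the step from compound 2 to compound 3 in this assay is expected to be small, near zero, and not clearly beyond the scatter in either direction, as a number 2 percentage points higher from compound 2 to compound 3 (within the scatter). Compound 3 is accordingly expected to give about 50% in this assay, within a range of 25% to 75%.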

Compound 3, a percentage reported as inhibition, in the whole organism at one dose (the size of the read-out at that dose, not a potency): 24%
Compound 3: the middle estimate sits 26 percentage points above what was measured; measured number outside the range, below it.
By their numbers in this assay, from the lowest: compound 3; then compounds 1 and 2 (each within the scatter of the next).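

Replacing hydrogen with (ethoxycarbonyl)amino on the aromatic carbon between two ring nitrogen atoms gives the series its first measured direction: in this assay, the change produces a number 24 percentage points lower from compound 2 to compound 3 (beyond the scatter). This position, which carries hydrogen in compound 2, is therefore not silent in the whole-organism read-out at the dose given, and substitution with this group lowers the inhibition rather than leaving it flat or raising it. Nothing available bears on the reason for this fall, and a single pair cannot separate the effect of this group from that of substitution at this position in general.

Still open, from the compounds shown here alone, is whether the fall follows the whole (ethoxycarbonyl)amino group or only part of it, which a simple amine or an acetylamino group on the same carbon would help to separate. Also open, going by these compounds, is whether a longer chain on the carbamate oxygen, or a carboxylic acid in place of the ethyl ester, would move the number in this assay further down or back towards the level of compound 2.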